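A few compounds are considered here, and "the series" means these few. Any claim that something is new, unique, unknown or untested is made for them only; others in the source may bear on it.

Measured so far in a functional assay on HepG2 cells (Homo sapiens) for inhibition, read by MTT assay, with a stated time of 48 h; a higher number here means a weaker inhibitor, a lower number a stronger inhibitor:
- compound 1 `CCOC(=O)C1=C(NN=C(C(C)=O)C(C)=O)Nc2[nH]nc(C)c2C1c1ccc(N(C)C)cc1`: 8480 nM
- compound 2 `CCOC(=O)C1=C(N/C=N/c2ccc([N+](=O)[O-])cc2)Nc2[nH]nc(C)c2C1c1ccc(N(C)C)cc1`: 50900 nM

Of these two compounds, compound 2 has the higher number, 50900 nM, which makes it the weaker inhibitor of the pair. For the measured compounds named here, the only measured step between them is a 6.0-fold higher number from compound 1 to compound 2 (0.78 log units; beyond the scatter).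

Compound 3 `CCOC(=O)C1=C(N/N=C(/C(C)=O)C(=O)OCC)Nc2[nH]nc(C)c2C1c1ccc(N(C)C)cc1` has not yet been measured. Its change from compound 2 sits on an amine nitrogen: a group of 10 heavy atoms (6 carbon, 1 nitrogen, 3 oxygen; no ring) in place of a group of 11 heavy atoms (7 carbon, 2 nitrogen, 2 oxygen; one six-membered aromatic ring of carbon only), on an amine nitrogen. The measured step of a 6.0-fold higher number from compound 1 to compound 2 (0.78 log units; beyond the scatter) is the only one that bears on this change, and it brought in the same group of 11 heavy atoms that now leaves. Going by the values given here, the group that enters has no ring, as in compound 1, but it is not the same group, and no measurement yet shows what that difference means. One step is thin support, but a step of similar size in the opposite direction is expected in this assay, towards a lower number, close to compound 1 at 8480 nM. The expected change is a 4.6-fold lower number from compound 2 to compound 3 (0.67 log units; beyond the scatter). For compound 3 the estimated value is 11000 nM, with an expected range of 4000 nM to 30000 nM.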

Compound 3, half-maximal inhibitory concentration: > 100000 nM
Compound 3: no number, only a limit; the forecaster's own chance of this, stated with the estimate: 3%; at least 9.0-fold (0.95 log units) between middle value and limit.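

In this assay compound 3 gives no number, only a limit: the limit of > 100000 nM in this assay, at which 1 of the 3 values shown sits.

The result shows that having no ring on this amine nitrogen does not by itself keep the number low, since two ringless groups that differ only in an ethyl ester where the other carries a second acetyl group are set apart by an at least 11-fold higher number from compound 1 to compound 3 (1.07 log units; beyond the scatter). This is the one comparison here in which a single change within the ringless side chain is seen, and it makes that ester-for-acetyl change the largest step shown at this position, while the swap of the group with the six-membered aromatic ring for the ringless ester group can only be given as a floor, an at least 1.9-fold higher number from compound 2 to compound 3 (0.29 log units; that floor lies within the scatter).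

As far as these compounds go, how far compound 3 lies past its limit stays unknown, so neither the full size of these steps nor the order of compound 2 and compound 3 beyond that floor can be settled. The compounds shown also leave open whether the loss follows the ethyl ester as such, and whether a carboxylic acid or an amide in its place would bring the number back towards that of compound 1.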